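Working notes: replacing the imidazole group of compound 3

A few compounds are considered here, and "the series" means these few. Any claim that something is new, unique, unknown or untested is made for them only; others in the source may bear on it.

In a physicochemical assay for lipophilicity, using the shake flask method, measured as octanol-water partition, at pH 7.4 (a higher number here means a more lipophilic compound, a lower number a more polar compound), compound 3 `CC(=O)N[C@@H]1CCC[C@H](C(=O)Nc2cc(-c3cnc(C)n3C)c(Cl)cn2)C1` gives 2.2. This is within the scatter of compound 1 `CC(=O)N[C@@H]1CCC[C@H](C(=O)Nc2cc(-c3cnn4c3CCCC4)ccn2)C1` at 2.4. Compound 2 `CC(=O)N[C@@H]1CCC[C@H](C(=O)Nc2cc(-c3cnn4c3CCCC4)c(F)cn2)C1` gives 2.9. The gap between compound 3 and compound 2 is beyond the scatter, with compound 3 the lower of the two.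

Compound 4 `CC(=O)N[C@@H]1CCC[C@H](C(=O)Nc2cc(-c3cnc4n3CCC4)c(Cl)cn2)C1` keeps the core of compound 3 and changes one group: a group of 8 heavy atoms (6 carbon, 2 nitrogen; one five-membered non-aromatic ring with 1 hetero atom, one five-membered aromatic ring with 2 hetero atoms) in place of a group of 7 heavy atoms (5 carbon, 2 nitrogen; one five-membered aromatic ring with 2 hetero atoms), on an aromatic carbon. The change sits on an aromatic carbon, ortho to a chloro group.

For the measured compounds named here, the only measured step, a number 0.50 log units higher from compound 1 to compound 2 (beyond the scatter), is a fluoro in place of hydrogen on an aromatic carbon. It is a modest step of a different kind, so it bears on this change only loosely. Going by the values given here, no measured pair covers a swap of this group, and compounds 1 and 3 differ in more than one place. Among the compounds with values here, with no direct precedent, a small upward step within the scatter is expected in this assay. The estimated step is a number 0.20 log units higher from compound 3 to compound 4 (within the scatter). The estimated value for compound 4 is 2.4, with an expected range from 2 to 2.8.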

Compound 4, distribution coefficient: 2.6
Beside the measured number, compound 4's estimate is 0.20 log units below it; low and high end bracket the measured number.
By their numbers in this assay, from the lowest: compounds 3, 1, 4 and 2 (each within the scatter of the next, the first and the last beyond it).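

At this position, on an aromatic carbon ortho to a chloro group, this assay responds to the swap of the 1,2-dimethyl-1H-imidazol-5-yl group for the group with the added five-membered non-aromatic ring, giving a number 0.40 log units higher from compound 3 to compound 4 (beyond the scatter). For the compounds shown here, this is the first measured step at this position, as the only earlier step was a fluoro in place of hydrogen at another place. Counts of hydrogen-bond donors and acceptors and the net charge stay the same across the swap, so the step appears without a change in any of them, and no measurement at hand accounts for it.

From the compounds shown here alone, whether the swap gives a step of like size with fluoro or hydrogen in place of the chloro group remains open. Also open, going by these compounds, is where the number would fall with a primary amine or a carboxylic acid on the added non-aromatic ring.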